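Opening the five-membered ring into a chain

A few compounds are considered here, and "the series" means these few. Any claim that something is new, unique, unknown or untested is made for them only; others in the source may bear on it.

Of the compounds shown here, three sharing one core have been measured in a functional assay for activation of Alpha-1A adrenergic receptor (Homo sapiens), read by calcium flux; on this read-out higher numbers stand for an effect only at larger amounts of compound and lower numbers for an effect already at smaller amounts. Compound 1 `Cc1nc(-c2ccccc2NCC2=NCCN2)co1` gives 324 nM, the highest of the three numbers. Compound 2 `Cc1cc(-c2ccccc2NCC2=NCCN2)on1` gives 38.9 nM, and compound 3 `CO/N=C/c1ccccc1NCC1=NCCN1` gives 51.3 nM. Replacing the five-membered aromatic ring of compound 1 brought an 8.3-fold lower number from compound 1 to compound 2 (0.92 log units; beyond the scatter) in one case and a 6.3-fold lower number from compound 1 to compound 3 (0.80 log units; beyond the scatter) in the other; the two replacements land close together, with a 1.3-fold higher number from compound 2 to compound 3 (0.12 log units; within the scatter).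

Compound 4 `CC/C(=N/OC)c1ccccc1NCC1=NCCN1` has not yet been measured. It differs from compound 1 in one place: a group of 6 heavy atoms (4 carbon, 1 nitrogen, 1 oxygen; no ring) in place of a group of 6 heavy atoms (4 carbon, 1 nitrogen, 1 oxygen; one five-membered aromatic ring with 2 hetero atoms), on an aromatic carbon. The group that enters is an open chain with a double bond, of the same kind as the group in compound 3, only larger.

The step from compound 1 to compound 3 bears most directly on this change, and it was modest but beyond the scatter. Within the data shown here, there is no measured pair that shows what enlarging such a chain does, so the expectation rests on that single step. Compound 4 is therefore expected to show a 4.6-fold lower number from compound 1 to compound 4 (0.67 log units; beyond the scatter). For compound 4 the estimate is 70 nM, with a range from 25 nM to 200 nM.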

Compound 4, half-maximal effective concentration: 87.1 nM
The estimate for compound 4 lay 1.2-fold (0.09 log units) below the measured number; low and high end bracket the measured number.
By their numbers in this assay, from the lowest: compounds 2, 3 and 4 (each within the scatter of the next, the first and the last beyond it); then compound 1.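

In this assay, a second open chain replacing the 2-methyl-1,3-oxazol-4-yl ring gives a 3.7-fold lower number from compound 1 to compound 4 (0.57 log units; beyond the scatter) and so shows that the lower number seen with compound 3 does not depend on that one small chain; here the entering chain has as many heavy atoms as the ring that leaves. Among these compounds, the first comparison of chain size, a 1.7-fold higher number from compound 3 to compound 4 (0.23 log units; within the scatter), stays within the scatter, so the larger chain on this aromatic carbon brings no measurable change from the smaller one. The comparison with the 3-methyl-1,2-oxazol-5-yl ring is less even, since a 2.2-fold higher number from compound 2 to compound 4 (0.35 log units; beyond the scatter) lies just beyond the scatter, whereas compound 2 and compound 3 stood within it, and the difference is small enough that only repeated measurements could firm it up.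

From the compounds shown here alone, what a longer chain, an amine or a carboxylic acid at this place would do remains open, so the limit of chain size on this position is still unknown. No measurement shown here explains why these groups give the numbers they do.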